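The source may hold more compounds than are shown below. What is called first, only, known or untested is meant among the compounds shown, and "the series" means these compounds.

In a functional assay on DLD-1 cells (Homo sapiens) for antiproliferative activity, read by CellTiter-Glo, with a stated time of 72 h (on this read-out higher numbers stand for weaker inhibition and lower numbers for stronger inhibition), compound 3 `Cc1cc(C)c(S(=O)(=O)N2CCC(N3CCCCC3)CC2)c(C)c1` gives 2200 nM, the highest of the three numbers measured here. Compound 1 `Cc1cc(C)c(S(=O)(=O)N2CCC(N3CCC(O)CC3)CC2)c(C)c1` gives 106 nM and compound 2 `Cc1cc(C)c(S(=O)(=O)N2CCC(N3CCC(C)OC3)CC2)c(C)c1` gives 92 nM. Compound 4 `CCCC(=O)NC1CCN(S(=O)(=O)c2c(C)cc(C)cc2C)CC1` differs from compound 3 in one place: (propylcarbonyl)amino in place of piperidin-1-yl on a saturated ring carbon. Among the measured compounds shown here, the steps that bear on this change are a 21-fold higher number from compound 1 to compound 3 (1.32 log units; beyond the scatter) and a 24-fold higher number from compound 2 to compound 3 (1.38 log units; beyond the scatter), both large and both toward weaker inhibition once the oxygen-containing group is gone. For the measured compounds named here, the incoming group again contains an oxygen, but the nitrogen of the piperidin-1-yl ring leaves with it, and no measured compound tests that loss, so the outlook is uncertain. Compound 4 is expected to give 600 nM, within a range from 120 nM to 3000 nM. The expected step is therefore a 3.7-fold lower number from compound 3 to compound 4 (0.56 log units; beyond the scatter), a partial gain only.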

Compound 4, half-maximal inhibitory concentration: > 5000 nM
Compound 4: only a limit was reported (the forecaster's own chance of this, stated with the estimate: 5%); middle value at least 8.3-fold (0.92 log units) away from the limit.
By their numbers in this assay, from the lowest: compounds 2 and 1 (each within the scatter of the next); then compound 3. At a limit, above all of these: compound 4.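

Compound 4 gives > 5000 nM, which is a limit and not a number. Replacing piperidin-1-yl with (propylcarbonyl)amino gives an at least 2.2-fold higher number from compound 3 to compound 4 (0.35 log units; beyond the scatter), so an oxygen in the incoming group does not by itself restore inhibition at this position. The steps from the two compounds with an oxygen-bearing ring are large: an at least 54-fold higher number from compound 2 to compound 4 (1.73 log units; beyond the scatter) and an at least 47-fold higher number from compound 1 to compound 4 (1.67 log units; beyond the scatter).

Compound 4 loses the ring and changes the attached nitrogen in one move, and these two changes cannot be told apart here. An open-chain amine or a ring carrying a carboxylic acid on this saturated ring carbon would remain to be tested.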